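Hydrogen in place of phenyl in compound 2

The source may hold more compounds than are shown below. What is called first, only, known or untested is meant among the compounds shown, and "the series" means these compounds.

compound 1 `Cn1cc(C2=C(c3nn(CCCn4cccc4)c4ncccc34)C(=O)NC2=O)c2ccccc21`: > 100000 nM (a limit)
compound 2 `Cn1cc(C2=C(c3nn(CCCn4ccnc4)c4ncccc34)C(=O)N(c3ccccc3)C2=O)c2ccccc21`: 6800 nM

For the measured compounds named here, in a functional assay on KB cells (Homo sapiens) for antiproliferative activity, read by MTT assay, with a stated time of 48 h (on this read-out lower numbers stand for stronger inhibition and higher numbers for weaker inhibition), compound 2 gives 6800 nM, the only exact number available. Compound 1 gives > 100000 nM, which is a limit of the assay. Compound 3 `Cn1cc(C2=C(c3nn(CCCn4ccnc4)c4ncccc34)C(=O)NC2=O)c2ccccc21` has hydrogen in place of phenyl on an amide-type nitrogen in a ring. Going by the values given here, no measured step covers this change. Weaker inhibition than in compound 2, beyond the usual scatter, is expected because compound 1 with hydrogen on that nitrogen gives > 100000 nM, again a limit. The expected change is a 3.7-fold higher number from compound 2 to compound 3 (0.57 log units; beyond the scatter). For compound 3 the estimated value is 25000 nM, with an expected range of 5000 nM to 100000 nM.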

Compound 3, half-maximal inhibitory concentration: > 100000 nM
Compound 3 gave a limit, no number; the forecaster's own chance of this, stated with the estimate: 30%; middle value at least 4.0-fold (0.60 log units) away from the limit.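

In this assay, replacing the phenyl on the amide-type nitrogen with hydrogen now has a direct measured step: an at least 14-fold higher number from compound 2 to compound 3 (1.16 log units; beyond the scatter), a large change beyond the scatter. For the compounds shown here, earlier, the only hint came from compound 1, which also differs from compound 2 in a second place. The value of compound 3 is a limit, so the full size of the step stays unknown, and the step between the 1H-imidazol-1-yl and 1H-pyrrol-1-yl groups cannot be read: the limit of > 100000 nM in this assay, at which 2 of the 3 values shown sit.

The compounds shown leave open whether a methyl or benzyl group on that nitrogen would give a measurable value.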